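Isopropylamino to cyclopropylamino on the shared core

A few compounds are considered here, and "the series" means these few. Any claim that something is new, unique, unknown or untested is made for them only; others in the source may bear on it.

Compound 1 `CCOc1nc(N)nc2c1ncn2/C=C1/CC1(CO)CO`: > 300000 nM (limit)
Compound 2 `Nc1nc(OCc2ccccc2)c2ncn(/C=C3/CC3(CO)CO)c2n1`: > 300000 nM (limit)
Compound 3 `CC(C)Nc1nc(N)nc2c1ncn2/C=C1/CC1(CO)CO`: > 300000 nM (limit)

In an ADME assay on HFF cells (Homo sapiens) for cytotoxicity, with a stated time of 8 days (a lower number here means that less compound is tolerated, a higher number that more compound is tolerated), compound 3 gives > 300000 nM, which is a limit and not a number. The results for compound 1 and compound 2 are limits too, so the series offers no numeric value.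

Compound 4 `Nc1nc(NC2CC2)c2ncn(/C=C3/CC3(CO)CO)c2n1` has not been measured. It carries cyclopropyl in place of isopropyl on a nitrogen on an aromatic ring.

The closest measured changes alter the group at this same place: a step that the two limits leave unreadable from compound 1 to compound 3 and a step that the two limits leave unreadable from compound 2 to compound 3. Neither has a readable size because of the limit of > 300000 nM in this assay, at which 3 of the 3 values shown sit. The remaining change, a step that the two limits leave unreadable from compound 1 to compound 2, adds no size either.

No direction is therefore expected in this assay, and no change beyond the scatter. The expected result is a number no higher from compound 3 to compound 4 (the limit leaves the size open). A further limit is the likeliest report. The estimate for compound 4 is 300000 nM, with an expected range of 100000 nM to 600000 nM.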

Compound 4, half-maximal cytotoxic concentration: > 300000 nM
Compound 4: a limit, no number; the forecaster's own chance of this, stated with the estimate: 75%; the middle value lies on the limit itself.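

In this assay compound 4 gives > 300000 nM, which is a limit and not a number. The steps to compound 4 from compound 1, compound 2 and compound 3 cannot be read because every value is a limit: the limit of > 300000 nM in this assay, at which 4 of the 4 values shown sit.

The compounds shown leave open whether any group at this place changes the result in this assay.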